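The compounds below may be only part of what the source reports. "The series", "measured", "known", "first", "only" and "open" are said of these compounds alone.

Measured compounds:
compound 1 `CCCn1c(=O)[nH]c2nc(-c3ccc(S(=O)(=O)N4CCN(Cc5cccc(Br)c5)CC4)cc3)[nH]c2c1=O` — 23%
compound 2 `CCCn1c(=O)c2[nH]c(-c3ccc(S(=O)(=O)N4CCN(c5ccc(Cl)cc5)CC4)cc3)nc2n(C)c1=O` — 39%

In an assay on CHO cells for displacement of a labelled ligand from adenosine receptor A3 (Homo sapiens), read by scintillation counting, with a stated time of 45 min, tested at 1 uM, in the presence of a further agent that is not named here (a lower number here means less inhibition, a higher number more inhibition at the concentration tested (going by the name of the read-out)), compound 1 gives 23% and sits lowest of the two numbers recorded. In this assay, going by the values given here, compound 2 gives 39%, a number beyond the usual scatter above compound 1; no step between these two is computed here, so only the two values themselves are noted.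

Compound 3 `CCCn1c(=O)[nH]c2nc(-c3ccc(S(=O)(=O)N4CCN(c5ccc(I)cc5)CC4)cc3)[nH]c2c1=O` has not yet been measured in this assay. Compound 3 differs from compound 1 by 4-iodophenyl in place of 3-bromobenzyl on an amine nitrogen in a ring. Among the compounds with values here, with no measured step to lean on, the expectation rests on the two values alone: compound 2, with its higher reading, is the only hint that a change at this ring nitrogen can go with a higher number, and that hint rests on a single value. A small upward step from compound 1 is expected, a number 10 percentage points higher from compound 1 to compound 3 (within the scatter), though a step within the scatter would not surprise. For compound 3 the estimated reading in this assay is 33%, with a range from 15% to 55%.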

Compound 3, a percentage reported as inhibition, at one concentration (the size of the read-out at that concentration, not a potency): 36%
Compound 3: the middle estimate sits 3 percentage points below what was measured; measured number inside the range.
By their numbers in this assay, from the lowest: compound 1; then compounds 3 and 2 (each within the scatter of the next).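

In this assay the swap of 3-bromobenzyl for 4-iodophenyl on an amine nitrogen in a ring gives a number 13 percentage points higher from compound 1 to compound 3 (beyond the scatter) with the rest of compound 1 unchanged, the first step read at this position. The group on this nitrogen can therefore move the reading on its own, even though both groups hold one six-membered aromatic ring of carbon only, with no hydrogen-bond donors or acceptors and no net charge. No measured property accompanies this step, and its origin remains unexplained.

Still open, on these data alone, is which part of the swap carries the step: the halogen, its place on the ring, or the benzyl carbon; a 4-bromophenyl or 3-iodobenzyl group would separate these. Also open, as far as these compounds go, is how an amine on that aromatic ring, or a longer chain on this nitrogen, would read.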